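Aryl substituent variation on the shared core, third member

This account rests on a few compounds, and the source may have more. Where it says the series, first, only, none or still open, it means among the compounds named here.

Two compounds of the series have been run in a functional assay on KBVIN cells (Homo sapiens) for antiproliferative activity, read by sulforhodamine B assay, with a stated time of 3 days; a higher number here means that more compound is needed for the effect, a lower number that less compound is needed. Compound 1 `CCC1=C(O)c2c(oc(-c3ccc(C(F)(F)F)cc3)cc2=O)C(CC)(CC)C1=O` gives 10.4 uM in this assay, and compound 2 `CCC1=C(O)c2c(oc(-c3ccc(COC)cc3)cc2=O)C(CC)(CC)C1=O` gives 3.4 uM. Within the data shown here, the only measured step is a 3.1-fold lower number from compound 1 to compound 2 (0.49 log units; beyond the scatter). Among the measured compounds shown here, compound 2 therefore stands at the lower of the two numbers so far, with compound 1 as its sole comparator.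

Compound 3 `CCC1=C(O)c2c(oc(-c3ccc(OC)c(C)c3)cc2=O)C(CC)(CC)C1=O` is the next member. Relative to compound 2 the change is 4-methoxy-3-methylphenyl in place of 4-(methoxymethyl)phenyl on an aromatic carbon. For the measured compounds named here, no measured step swaps one aryl group for another of this kind, so the single step from compound 1 to compound 2 bears on it only indirectly: it shows that an exchange of the substituent on this aryl ring can move this assay by a modest amount, without telling in which direction a change of this particular sort would go. A step of modest size in either direction, or none beyond the scatter, is plausible. Compound 3 is expected at 4 uM, within a range of 1.5 uM to 12 uM. The step from compound 2 that this estimate implies is a 1.2-fold higher number from compound 2 to compound 3 (0.07 log units; within the scatter), taken as the expectation until a measurement exists.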

Compound 3, concentration for half-maximal effect: 0.1 uM
The estimate for compound 3 lay 40-fold (1.60 log units) above the measured number, outside the stated range (below it).
By their numbers in this assay, from the lowest: compound 3; then compound 2; then compound 1.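

In this assay, exchanging one aryl group on the shared core for another can move the number much further than the earlier step indicated: a 34-fold lower number from compound 2 to compound 3 (1.53 log units; beyond the scatter), set against a 3.1-fold lower number from compound 1 to compound 2 (0.49 log units; beyond the scatter). The leaving and entering groups have the same atoms and the same counts of donors and acceptors, so at this position the atom composition of the aryl group does not by itself set the number; 4-methoxy-3-methylphenyl and 4-(methoxymethyl)phenyl differ only in how those atoms are joined. Nothing at hand accounts for a step of this size from such a rearrangement.

Still open, from the compounds shown here alone, is which part of the change goes with the step: the methoxy group bonded directly to the ring, the added ring methyl, or only the two together, a question that a 4-methoxyphenyl or a 3-methylphenyl group on the same core would separate. Also open, going by these compounds, is whether an ethoxy or a dimethylamino group in place of the methoxy group would stay close to compound 3 at 0.1 uM.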